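The source may hold more compounds than are shown below. What is called first, only, known or untested is meant among the compounds shown, and "the series" means these compounds.

The series shares the core of compound 2 `COc1ccc(-c2cc3ccccc3nc2/C=C/C(=O)c2ccc([N+](=O)[O-])cc2)cc1` and varies the group attached to the carbonyl carbon. In a functional assay on MDA-MB-231 cells (Homo sapiens) for antiproliferative activity, read by XTT assay, with a stated time of 72 h (on this read-out lower numbers stand for stronger inhibition and higher numbers for weaker inhibition), compound 2 gives 840 nM, the lowest of the two numbers recorded so far; its nearest neighbour is compound 1 `COc1ccc(-c2cc3ccccc3nc2/C=C/C(=O)c2c(OC)cccc2OC)cc1`, which in this assay gives 5630 nM. For the measured compounds named here, the single measured step, a 6.7-fold lower number from compound 1 to compound 2 (0.83 log units; beyond the scatter), shows that exchanging the aryl on the carbonyl carbon moves the read-out beyond the scatter. Compound 3 `COc1ccc(-c2cc3ccccc3nc2/C=C/C(=O)c2ccc[nH]2)cc1` carries the change (1H-pyrrol-2-yl in place of 4-nitrophenyl on a carbonyl carbon). Going by the values given here, only the step from compound 1 to compound 2 concerns this position, and both of its groups differ from the incoming pyrrolyl, so it indicates the size an exchange here can take but not the direction this one will follow. A shift of comparable size either way is plausible; the working expectation is a number between the two measured values, somewhat weaker than compound 2. The expected step is therefore a 2.4-fold higher number from compound 2 to compound 3 (0.38 log units; beyond the scatter). Compound 3 is estimated at 2000 nM, within 500 nM to 8000 nM.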

Compound 3, half-maximal inhibitory concentration: > 10000 nM
Compound 3: only a limit was reported (the forecaster's own chance of this, stated with the estimate: 5%); at least 5.0-fold (0.69 log units) between middle value and limit.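

In this assay compound 3 gives > 10000 nM, which is a limit of the assay and not a number. The position therefore tolerates poorly the move away from 4-nitrophenyl to a five-membered aromatic ring carrying a hydrogen-bond donor, with an at least 11-fold higher number from compound 2 to compound 3 (1.07 log units; beyond the scatter), so the exchange on the carbonyl carbon can cost activity as well as gain it. Against 2,6-dimethoxyphenyl the reading is an at least 1.7-fold higher number from compound 1 to compound 3 (0.24 log units; that floor lies within the scatter), so no order between those two groups can be stated, only 4-nitrophenyl stands apart from both, and the picture rests on one value that is only bounded: the limit of > 10000 nM in this assay, at which 1 of the 3 values shown sits.

Ring size, the hydrogen-bond donor and the loss of the nitro group all change together in this step, and the compounds shown do not separate them. From the compounds shown here alone, how an unsubstituted phenyl, a 4-aminophenyl or a 1-methylpyrrol-2-yl on the carbonyl carbon would read remains open, and these would show whether the nitro group or the pyrrole hydrogen matters more here.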